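Swapping the Halogen on the Sulfonyl Ring of Compound 2

The source may report more compounds than this note shows. Statements on the series, on what has been measured and on what is new or still open speak of the compounds shown alone.

Measured so far:
- compound 1, `O=C(NCc1ccc(CNS(=O)(=O)c2ccccc2F)cc1)c1cccnc1`, 100 nM
- compound 2, `COc1ccccc1C(=O)NCc1ccc(CNS(=O)(=O)c2ccccc2F)cc1`, 1 nM
- compound 3, `O=C(NCc1ccc(CNS(=O)(=O)c2cccc3ccccc23)cc1)c1cccnc1`, 1000 nM

In an assay on MDA-MB-231 cells for displacement of a labelled ligand from C-X-C chemokine receptor type 4 (Homo sapiens), read by fluorescence and microscopy, with stated times of 10 min and 30 min (on this read-out higher numbers stand for an effect only at larger amounts of compound and lower numbers for an effect already at smaller amounts), compound 2 gives the lowest of the three numbers. The nearest is compound 1 with a 100-fold lower number from compound 1 to compound 2 (2.00 log units; beyond the scatter), and the furthest is compound 3, which sits a further a 10-fold higher number from compound 1 to compound 3 (1.00 log units; beyond the scatter) from compound 1.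

Compound 4, `COc1ccccc1C(=O)NCc1ccc(CNS(=O)(=O)c2ccccc2Cl)cc1`, differs from compound 2 in one place: chloro in place of fluoro on an aromatic carbon. The change sits on an aromatic carbon of a six-membered aromatic ring of carbon only, ortho to a large group.

Among the compounds with values here, no measured pair swaps fluoro for chloro. Within the data shown here, the only step touching the same part of the molecule is a 10-fold higher number from compound 1 to compound 3 (1.00 log units; beyond the scatter), where the whole 2-fluorophenyl became naphthalen-1-yl, a much larger change than a single halogen swap. Compound 2 is therefore expected to keep most of its standing, and the step of a 1.5-fold higher number from compound 2 to compound 4 (0.18 log units; within the scatter) is expected to stay within or just beyond the scatter. Compound 4 is estimated at 1.5 nM, with a range of 0.4 nM to 6 nM.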

Compound 4, effective concentration (reported as EC, without a stated level of effect): 100 nM
The estimate for compound 4 lay 67-fold (1.82 log units) below the measured number, outside the stated range (above it).
By their numbers in this assay, from the lowest: compound 2; then compounds 1 and 4 (each within the scatter of the next); then compound 3.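

In this assay, chloro in place of fluoro on this aromatic carbon is far from a minor edit: it gives a 100-fold higher number from compound 2 to compound 4 (2.00 log units; beyond the scatter), so a higher number now means much more compound is needed for the same effect. This one-atom change has the same size as a 100-fold lower number from compound 1 to compound 2 (2.00 log units; beyond the scatter), where an entire ring group on the carbonyl carbon is replaced, so small edits on the sulfonyl ring can matter as much as large ones elsewhere. Nothing available explains why this single halogen counts for so much.

As far as these compounds go, whether a bromo, a methyl or a plain hydrogen on this carbon would fall nearer compound 2 or compound 4 stays open. Also open, from the compounds shown here alone, is whether the same halogen swap would carry the same penalty with the pyridin-3-yl group of compound 1 on the carbonyl carbon.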